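Swapping a chloroethyl arm for a phenylethenyl one

The compounds below may be only part of what the source reports. "The series", "measured", "known", "first", "only" and "open" are said of these compounds alone.

Of the compounds shown here, two have been measured so far. Compound 1 `CN(C)c1ccc(C2CC(c3ccc(-n4ccnc4)cc3)=NN2)cc1` gives -20.9% in a functional assay on HCC1806 cells (Homo sapiens) for inhibition, read by sulforhodamine B assay, tested at 10 uM (a higher number here means more inhibition at the concentration tested (going by the name of the read-out), a lower number less inhibition), a reading below zero. Compound 2 `CN1CCN(c2ccc(C3=NN(C(=O)CCCl)C(c4ccc(N(C)C)cc4)C3)cc2)CC1` gives 1.7% in this assay, and so stands highest of the two numbers, with compound 1 the nearest at a distance beyond the usual scatter. The two differ in more than one place, so their values are only compared, not traced to a single change.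

Compound 3 `CN1CCN(c2ccc(C3=NN(C(=O)/C=C/c4ccccc4)C(c4ccc(N(C)C)cc4)C3)cc2)CC1` has not yet been measured. It departs from compound 2 in one place (2-phenylethenyl in place of 2-chloroethyl on a carbonyl carbon), the group that enters bringing one six-membered aromatic ring of carbon only and one double bond outside aromatic rings. For the measured compounds named here, no measured step of this kind exists here, so any expectation rests on the low readings of compound 2 alone. Compound 3 is expected at 10%, within -15% to 35%, a step of a number 8.3 percentage points higher from compound 2 to compound 3 (within the scatter) that is estimated to be small and upward but possibly within the scatter.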

Compound 3, a percentage reported as inhibition, at one concentration (the size of the read-out at that concentration, not a potency): 71%
Beside the measured number, compound 3's estimate is 61 percentage points below it; the measured number lies above the stated range.
By their numbers in this assay, from the lowest: compound 1; then compound 2; then compound 3.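

Replacing 2-chloroethyl with 2-phenylethenyl on a carbonyl carbon gives a number 69.3 percentage points higher from compound 2 to compound 3 (beyond the scatter) in this assay. For the compounds shown here, this is the first step here that can be traced to a single change, and it shows that the group at this place has a large effect on the reading, with the rest of the molecule unchanged. Nothing available explains why this step is so large.

As far as these compounds go, whether the six-membered aromatic ring or the double bond outside aromatic rings carries the step stays open: a 2-phenylethyl group would keep the ring without the double bond, and a propenyl group would keep the double bond without the ring. Also open, from the compounds shown here alone, is how a methoxy group or an amine on that ring would change the reading.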